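Ethyl in place of bromo on the pendant phenyl

The source may hold more compounds than are shown below. What is called first, only, known or untested is meant among the compounds shown, and "the series" means these compounds.

Compound 1, `CC(=O)Nc1cccc(C2CCN(CCCn3c(-c4ccccc4Cl)nc4ccccc43)CC2)c1`, in an assay for displacement of a labelled ligand from melanin-concentrating hormone receptor 1 (Homo sapiens), read by fluorescence; a higher number here means a weaker inhibitor, a lower number a stronger inhibitor: 10 nM
Compound 2, `CC(=O)Nc1cccc(C2CCN(CCCn3c(-c4cccc(Cl)c4)nc4ccccc43)CC2)c1`, in this assay: 5 nM
Compound 3, `CC(=O)Nc1cccc(C2CCN(CCCn3c(-c4ccc(Br)cc4)nc4ccccc43)CC2)c1`, in this assay: 5 nM

Three measured compounds share one core and differ only in the substituent on the phenyl ring attached to it. Compound 3 stands level with compound 2, the two together giving the lowest numbers of the three; the step of no change at the digits printed from compound 2 to compound 3 (within the scatter), and the step of a 2.0-fold lower number from compound 1 to compound 3 (0.30 log units; within the scatter), both lie within the scatter, so compound 3 is not distinguishable from either neighbour on these numbers.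

Compound 4, `CCc1ccc(-c2nc3ccccc3n2CCCN2CCC(c3cccc(NC(C)=O)c3)CC2)cc1`, has not yet been measured in this assay. It differs from compound 3 by ethyl in place of bromo on an aromatic carbon. For the measured compounds named here, none of the measured steps changes a halogen for a carbon chain; the steps of a 2.0-fold lower number from compound 1 to compound 2 (0.30 log units; within the scatter) and a 2.0-fold lower number from compound 1 to compound 3 (0.30 log units; within the scatter) only move or exchange halogens, and each remained within the scatter. Those steps therefore give no sign that this ring position is sensitive, but they do not cover the present change either. The expected step of a 1.2-fold higher number from compound 3 to compound 4 (0.08 log units; within the scatter) is thus small, with no direction preferred beyond the scatter. Compound 4 is estimated at 6 nM, in the range 2 nM to 18 nM.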

Compound 4, half-maximal inhibitory concentration: 32 nM
Compound 4: the middle estimate sits 5.3-fold (0.73 log units) below what was measured; the measured number lies above the stated range.
By their numbers in this assay, from the lowest: compounds 2, 3 and 1 (each within the scatter of the next); then compound 4.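

In this assay, for the compounds shown here, the exchange of bromo for ethyl on the pendant phenyl gives a 6.4-fold higher number from compound 3 to compound 4 (0.81 log units; beyond the scatter) and is the one single-group change here that lies beyond the scatter, so this position, which looked indifferent while only halogens were moved or exchanged, does respond to what stands on it. Going by these compounds alone, compound 4 also stands apart from the other two, with a 6.4-fold higher number from compound 2 to compound 4 (0.81 log units; beyond the scatter) and with a 3.2-fold higher number from compound 1 to compound 4 (0.51 log units; beyond the scatter) as well, although those two steps change the position of the substituent together with the group, and only the step from the bromo compound reads the group alone. Nothing available accounts for this rise.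

On these data alone, with a single carbon substituent, it remains open whether the rise belongs to ethyl alone or to carbon chains at this position in general, which methyl or a longer chain such as propyl would help to settle. As far as these compounds go, it is equally open whether ethyl would read the same at the other two ring positions, and how an amine or a carboxylic acid would fare at this one.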